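The source may hold more compounds than are shown below. What is called first, only, known or untested is meant among the compounds shown, and "the series" means these compounds.

Measured in a functional assay on the whole organism for inhibition, with Mus musculus as the target; a higher number here means that more compound is needed for the effect, a lower number that less compound is needed:
- compound 1 `CCCCNC(=O)Nc1cccc2c1CN(C)CC2c1ccccc1`: about 40 mg/kg
- compound 2 `CCCCOC(=O)Nc1cccc2c1CN(C)CC2c1ccccc1`: 4 mg/kg
- compound 3 `CCCCNCC(=O)Nc1cccc2c1CN(C)CC2c1ccccc1`: 32 mg/kg

Compound 3 sits at the upper end of these three numbers, without separation from its nearest neighbour: a 1.3-fold lower number from compound 1 to compound 3 (0.10 log units; within the scatter). The gap on the other side is clear: an 8.0-fold higher number from compound 2 to compound 3 (0.90 log units; beyond the scatter).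

Next in the series is compound 4 `CN1Cc2c(NC(=O)CN3CCCC3)cccc2C(c2ccccc2)C1`, with pyrrolidin-1-yl in place of butylamino on a saturated chain carbon bound to a carbonyl carbon.

Among the measured compounds shown here, no measured step makes this exchange, so the evidence is indirect. The closest steps alter the group on the carbonyl carbon. Only the butoxy exchange moves this assay beyond the scatter: a 10-fold lower number from compound 1 to compound 2 (1.00 log units; beyond the scatter). Compound 4 keeps the amide and the aminomethyl link of compound 3, so no step beyond the scatter is expected. The estimated step is a 1.3-fold lower number from compound 3 to compound 4 (0.11 log units; within the scatter). From the compounds shown here alone, the range stays wide because a 10-fold lower number from compound 1 to compound 2 (1.00 log units; beyond the scatter) shows that this part of the series can respond, and a ring at this place is untested.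

Compound 4 is estimated at 25 mg/kg, with an expected range of 8 mg/kg to 80 mg/kg.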

Compound 4, dose for half-maximal effect: 39 mg/kg
Beside the measured number, compound 4's estimate is 1.6-fold (0.19 log units) below it, within the range that was stated.
By their numbers in this assay, from the lowest: compound 2; then compounds 3, 4 and 1 (each within the scatter of the next).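

In this assay, replacing butylamino with pyrrolidin-1-yl on a saturated chain carbon bound to a carbonyl carbon brings in a five-membered non-aromatic ring and removes the hydrogen-bond donor of that group, yet the step stays within the scatter (a 1.2-fold higher number from compound 3 to compound 4 (0.09 log units; within the scatter)). This place therefore tolerates the ring for this read-out, and the (pyrrolidin-1-yl)methyl group also shows no separation from the butylamino group of the urea (a 1.0-fold lower number from compound 1 to compound 4 (0.01 log units; within the scatter)), while the butoxy compound remains clearly apart (a 9.8-fold higher number from compound 2 to compound 4 (0.99 log units; beyond the scatter)). No measured evidence bears on why this exchange leaves the number unchanged within the scatter.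

From the compounds shown here alone, whether piperidin-1-yl, morpholin-4-yl or dimethylamino would also stay within the scatter remains open. Also open, going by these compounds, is whether a longer chain between the carbonyl and the amine would move the number towards that of compound 2.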